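Triazole aryl swap in a tosylate series: methyl for methoxy

The source may report more compounds than this note shows. Statements on the series, on what has been measured and on what is new or still open speak of the compounds shown alone.

Compound 2 `C=C1C[C@]23C[C@@]1(O)CC[C@H]2c1ccc(OS(=O)(=O)c2ccc(C)cc2)c(C)c1[C@@H]3Cn1cc(-c2ccc(OC)cc2)nn1` is known only as a limit in a functional assay on MCF7 cells (Homo sapiens) for cytotoxicity, read by MTT assay, with a stated time of 4 days; on this read-out lower numbers stand for stronger inhibition and higher numbers for weaker inhibition: compound 2 gives > 20000 nM, a limit of the assay rather than a number. Compound 1 `C=C1C[C@]23C[C@@]1(O)CC[C@H]2c1ccc(OS(=O)(=O)c2ccc(C)cc2)c(C)c1[C@@H]3Cn1cc(-c2ccc(Br)cc2)nn1` gives > 20000 nM, again a limit. For the measured compounds named here, the step that the two limits leave unreadable from compound 1 to compound 2 is therefore unreadable; the only evidence is the limit of > 20000 nM in this assay, at which 2 of the 2 values shown sit. Compound 3 `C=C1C[C@]23C[C@@]1(O)CC[C@H]2c1ccc(OS(=O)(=O)c2ccc(C)cc2)c(C)c1[C@@H]3Cn1cc(-c2ccc(C)cc2)nn1` differs from compound 2 by methyl in place of methoxy on an aromatic carbon. No readable step bears on this change, and with both known values at the limit compound 3 is expected to remain at the limit in this assay. The step that the limit leaves unreadable from compound 2 to compound 3 is expected to be none beyond the scatter. Compound 3 is estimated at 40000 nM, between 15000 nM and 120000 nM.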

Compound 3, half-maximal inhibitory concentration: > 20000 nM
Compound 3: only a limit was reported; the forecaster's own chance of this, stated with the estimate: 85%; the middle value is on the limit's open side.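

For the compounds shown here, compound 3 gives > 20000 nM, a limit and not a number, so no step among compound 1, compound 2 and compound 3 can be read. Still open, going by these compounds, is how far these compounds lie beyond the limit, and whether any other group in this place would give a readable value.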